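A few compounds are considered here, and "the series" means these few. Any claim that something is new, unique, unknown or untested is made for them only; others in the source may bear on it.

Compound 1 `N#Cc1ccccc1CN1CCc2c(sc(NC(=O)c3ccccc3Cl)c2C(N)=O)C1`, compound 2 `NC(=O)c1c(NC(=O)c2ccccc2Cl)sc2c1CCN(Cc1ccccc1F)C2` and compound 3 `NC(=O)c1c(NC(=O)c2ccccc2F)sc2c1CCN(Cc1cccc(Cl)c1)C2` share one core and differ only in the groups carried on it. In a functional assay on MKN-74 cells (Homo sapiens) for antiproliferative activity, with a stated time of 24 h (a lower number here means a stronger inhibitor, a higher number a weaker inhibitor), compound 1 gives 9500 nM, compound 2 gives 12900 nM and compound 3 gives 23300 nM. Among the compounds with values here, the one step that can be read directly is a 1.4-fold higher number from compound 1 to compound 2 (0.13 log units; within the scatter), and in this assay compound 2 stands second highest of the three numbers, nearest to compound 1 and furthest from compound 3, both of those gaps within the scatter.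

Compound 4 `NC(=O)c1c(NC(=O)c2ccccc2Cl)sc2c1CCN(C(=S)Nc1c(Cl)cccc1Cl)C2` has not yet been measured in this assay. Against compound 2 the change is a group of 11 heavy atoms (7 carbon, 1 nitrogen, 1 sulfur, 2 chlorine; one six-membered aromatic ring of carbon only) in place of a group of 8 heavy atoms (7 carbon, 1 fluorine; one six-membered aromatic ring of carbon only), on an amine nitrogen in a ring. Within the data shown here, no measured step bears on this change: the only step available exchanges one group on an aromatic carbon for another and is within the scatter, whereas here the whole group on the ring amine nitrogen is exchanged for one of a different kind. The three measured numbers all lie close together, so there is no ground in them for expecting a step beyond the scatter in either direction.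

Compound 4 is therefore expected to give about 10000 nM in this assay, with a range of 3000 nM to 35000 nM. The step this estimate implies is a 1.3-fold lower number from compound 2 to compound 4 (0.11 log units; within the scatter).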

Compound 4, half-maximal inhibitory concentration: 4020 nM
Estimate against measurement, compound 4: 2.5-fold (0.40 log units) above, and the stated range covers the measured number.
By their numbers in this assay, from the lowest: compound 4; then compounds 1, 2 and 3 (each within the scatter of the next, the first and the last beyond it).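

In this assay, within the data shown here, the amine nitrogen in a ring now shows a step beyond the scatter, which the one earlier step, made on an aromatic carbon, did not: there is a 3.2-fold lower number from compound 2 to compound 4 (0.51 log units; beyond the scatter) and also a 2.4-fold lower number from compound 1 to compound 4 (0.37 log units; beyond the scatter), both modest and both in the same direction. Compounds 1 and 2 carry a benzyl-type group at this place, so compound 4 shows that a group of a different kind, with a double bond outside aromatic rings, a hydrogen-bond donor and a hydrogen-bond acceptor, is not only accepted here but gives the lowest number of the series against both of these neighbours. No measurement shown here accounts for this shift in the numbers.

The sulfur, the nitrogen-hydrogen and the two chlorines all enter together, so the compounds shown cannot say which of them carries the step. Going by these compounds, a urea with oxygen in place of the sulfur, or a plain phenyl ring without the chlorines, would separate these parts, and it remains open whether the step would hold with the 2-fluorobenzoyl amide of compound 3.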